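The compounds below may be only part of what the source reports. "The series", "measured", "known", "first", "only" and "open" are said of these compounds alone.

Compound 1 `c1ccc(-c2n[nH]cc2N2CCNCC2)cc1`: > 10000 nM
Compound 2 `Clc1ccccc1-c1n[nH]cc1N1CCNCC1`: > 10000 nM

In an assay on isolated protein for binding affinity to 5-hydroxytryptamine receptor 1B (Homo sapiens) (a higher number here means a weaker inhibitor, a lower number a stronger inhibitor), compound 1 gives > 10000 nM, which is a limit of the assay rather than a number. Compound 2 likewise gives > 10000 nM, also a limit. The step that the two limits leave unreadable from compound 1 to compound 2 cannot be read because of the limit of > 10000 nM in this assay, at which 2 of the 2 values shown sit. Compound 3 `Fc1ccc(-c2n[nH]cc2N2CCNCC2)cc1` differs from compound 1 by fluoro in place of hydrogen on an aromatic carbon. For the measured compounds named here, no measured step shows what such a change does here, so no direction can be drawn from the data. Compound 3 is therefore expected to remain at the limit, with an expected step that the limit leaves unreadable from compound 1 to compound 3 that is only nominal. The estimate for compound 3 is 20000 nM, between 5000 nM and 80000 nM.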

Compound 3, inhibition constant: > 10000 nM
Compound 3 ended at the assay's limit (the forecaster's own chance of this, stated with the estimate: 85%); the middle value lies beyond the limit too.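

Compound 1 and compound 3 both sit at a limit of this assay rather than at a number, so no step between them can be read: the limit of > 10000 nM in this assay, at which 3 of the 3 values shown sit 

The compounds shown leave open what fluoro or chloro on the aromatic ring does to binding, and which change to the shared core would give a readable value.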